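A few compounds are considered here, and "the series" means these few. Any claim that something is new, unique, unknown or untested is made for them only; others in the source may bear on it.

Measured compounds:
compound 1, `C#CCN(CCCOc1ccc2ccc(=O)oc2c1)Cc1ccc(C)cc1`, 7380 nM
compound 2, `C#CCN(CCCCOc1ccc2ccc(=O)oc2c1)Cc1ccc(C)cc1`, 1680 nM

Of the compounds shown here, two have so far been measured in an assay on isolated protein for inhibition of Amine oxidase [flavin-containing] B (Homo sapiens), read by fluorescence and Amplex Red, with stated times of 15 min and 20 min; a lower number here means a stronger inhibitor, a higher number a weaker inhibitor. Compound 1 `C#CCN(CCCOc1ccc2ccc(=O)oc2c1)Cc1ccc(C)cc1` gives 7380 nM, the higher of the two numbers, so on what has been measured it is the weaker inhibitor. Compound 2 `C#CCN(CCCCOc1ccc2ccc(=O)oc2c1)Cc1ccc(C)cc1` gives 1680 nM, and the gap between the two lies beyond the usual scatter. Among the measured compounds shown here, no pair of measured compounds differs in a single place, so no measured step can be read off.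

Compound 3 `C#CCN(CCCOc1ccc2ccc(=O)oc2c1)Cc1cccc(F)c1` has not yet been measured. It differs from compound 1 in one place: 3-fluorophenyl in place of 4-methylphenyl on a saturated chain carbon bound to an amine nitrogen. Nothing measured here shows how this change acts, so the expected step is a 1.2-fold lower number from compound 1 to compound 3 (0.09 log units; within the scatter), a small one that may fall within the scatter and in no firm direction. Compound 3 is therefore expected to give about 6000 nM in this assay, within a range from 2000 nM to 18000 nM.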

Compound 3, half-maximal inhibitory concentration: 4440 nM
Compound 3: the middle estimate sits 1.4-fold (0.13 log units) above what was measured; the range from low to high includes it.
By their numbers in this assay, from the lowest: compound 2; then compounds 3 and 1 (each within the scatter of the next).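

In this assay, 3-fluorophenyl in place of 4-methylphenyl on a saturated chain carbon bound to an amine nitrogen gives a 1.7-fold lower number from compound 1 to compound 3 (0.22 log units; within the scatter) and so brings no change that can be told from the scatter. This position therefore accepts this exchange without a clear effect on the number, but the two groups differ both in their substituent and in where it sits on the ring, so the step cannot be divided between the two. Nothing available here bears on why the step is this small.

The compounds shown leave open how 4-fluorophenyl or 3-methylphenyl would read at this position, either of which would separate those two differences. They also leave open whether 3-fluorophenyl would give a similar step on the longer chain of compound 2.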